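The source may hold more compounds than are shown below. What is called first, only, known or untested is meant among the compounds shown, and "the series" means these compounds.

Of the compounds shown here, three have been measured in a functional assay on MIA PaCa-2 cells (Homo sapiens) for inhibition, read by MTT assay, with a stated time of 72 h; on this read-out higher numbers stand for weaker inhibition of growth and lower numbers for stronger inhibition of growth. Compound 1 `O=S(=O)(NCCNCc1cccc2ccccc12)c1cc(C(F)(F)F)cc(C(F)(F)F)c1` gives 26000 nM in this assay. Compound 2 `O=S(=O)(NCCCNCc1ccccc1Cl)c1cc(C(F)(F)F)cc(C(F)(F)F)c1` gives 11000 nM in this assay, and compound 3 `O=[N+]([O-])c1ccc(S(=O)(=O)NCCCCCCNCc2ccc(Br)cc2)cc1` gives 9800 nM in this assay. Among these three numbers compound 2 stands second highest: its nearest neighbour is compound 3, whose number lies within the scatter of it, so the two cannot be ordered, while compound 1 carries a number beyond the scatter above compound 2, so compound 1 sits apart from the other two.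

Compound 4 `O=S(=O)(NCCCNCc1ccc(Cl)c(Cl)c1)c1cc(C(F)(F)F)cc(C(F)(F)F)c1` has not yet been measured in this assay. It differs from compound 2 in one place: 3,4-dichlorophenyl in place of 2-chlorophenyl on a saturated chain carbon bound to an amine nitrogen. Among the compounds with values here, no pair of measured compounds differs by this change alone, and the three measured compounds differ from one another in more than one place at once, so no measured step gives the direction. The expectation for this assay is a small step downward in number, near the edge of the scatter, from compound 2 to compound 4, namely a 1.7-fold lower number from compound 2 to compound 4 (0.23 log units; within the scatter). Compound 4 is accordingly estimated at 6500 nM in this assay, with a range from 2500 nM to 16000 nM.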

Compound 4, concentration for 50% growth inhibition: 2700 nM
Beside the measured number, compound 4's estimate is 2.4-fold (0.38 log units) above it; the measured number falls inside the stated range.
By their numbers in this assay, from the lowest: compound 4; then compounds 3 and 2 (each within the scatter of the next); then compound 1.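

In this assay, within the data shown here, 3,4-dichlorophenyl in place of 2-chlorophenyl on a saturated chain carbon bound to an amine nitrogen gives a 4.1-fold lower number from compound 2 to compound 4 (0.61 log units; beyond the scatter), the first step that can be read from a change in one place, and it shows that the number responds to the group carried at this position. The change is small by count, since the entering group has 8 heavy atoms where the leaving group has 7 and neither carries a hydrogen-bond donor, a hydrogen-bond acceptor or a net charge, yet the step lies beyond the scatter. Nothing in the data shown explains this step.

The step alters the number of chlorine atoms and their placement on the ring together, so the compounds shown cannot separate the two, and they do not tell how bromine or a methoxy group would compare with chlorine here. They also leave open whether a step of this size would hold on a longer chain or with a nitro group in place of the two trifluoromethyl groups.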